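The source may hold more compounds than are shown below. What is called first, only, known or untested is meant among the compounds shown, and "the series" means these compounds.

Measured so far in a functional assay on U-373MG ATCC cells for cytotoxicity against U373 MG (Homo sapiens), read by colorimetric assay and MTT assay; a higher number here means a weaker inhibitor, a lower number a stronger inhibitor:

compound 1, `COc1ccc(-c2cc3c(OC)cc(OC)cc3n(C)c2=O)cc1` — 10000 nM
compound 2, `CCOC(=O)Cn1c(=O)c(-c2ccc(OC)cc2)cc2c(OC)cc(OC)cc21` — 10000 nM
compound 3, `COc1ccc(-c2cc3c(OC)cc(OC)cc3n(CC#N)c2=O)cc1` — 10000 nM

In this assay compound 1 gives 10000 nM and stands level with compound 2 and compound 3 at the digits shown; its nearest neighbour is compound 2 and its furthest compound 3, both within the scatter. The three measured steps all sit on the saturated chain carbon bound to the aromatic nitrogen: no change at the digits printed from compound 1 to compound 2 (within the scatter), no change at the digits printed from compound 1 to compound 3 (within the scatter) and no change at the digits printed from compound 2 to compound 3 (within the scatter). None of them moved the read-out.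

Compound 4, `COc1cc(OC)c2cc(-c3ccc(OC(C)=O)cc3)c(=O)n(C)c2c1`, differs from compound 1 elsewhere: acetyl in place of methyl on an oxygen on an aromatic ring. For the measured compounds named here, no measured step touches the oxygen on the aromatic ring, so there is no direct precedent for this change. Going by the values given here, the only guidance is that every variation measured so far left the series at one level. The expected step is therefore no change at the digits printed from compound 1 to compound 4 (within the scatter), none beyond the scatter. Compound 4 is expected at 10000 nM, with a range from 4000 nM to 25000 nM.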

Compound 4, half-maximal inhibitory concentration: 10000 nM
The estimate for compound 4 equals the measured number at the digits printed; measured number inside the range.
By their numbers in this assay, from the lowest: compounds 1, 2, 3 and 4 (each within the scatter of the next).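

Methoxy to acetoxy is the first change away from the chain on the aromatic nitrogen, and in this assay it shows no change at the digits printed from compound 1 to compound 4 (within the scatter) for this swap. The level of the series therefore also holds for this one change on an oxygen on an aromatic ring, even though acetyl brings a double bond outside aromatic rings and a hydrogen-bond acceptor that methyl lacks. No available data bear on why the read-out stays the same here.

From the compounds shown here alone, whether a free hydroxyl, an amine or a longer ester chain in this place would move the read-out stays open. Going by these compounds, it is also open whether a change at the other methoxy groups on the shared core would leave the read-out at the same level.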